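A few compounds are considered here, and "the series" means these few. Any claim that something is new, unique, unknown or untested is made for them only; others in the source may bear on it.

- compound 1 `CCCCCCCC[C@@H](CCO)n1cnc2c(Cl)ncnc21` gives 2330 nM
- compound 2 `CCCCCCCCC[C@H](CCO)n1cnc2c(Cl)ncnc21` gives 1630 nM

In a functional assay on SW480 cells (Homo sapiens) for antiproliferative activity, read by MTT assay, with a stated time of 48 h (on this read-out higher numbers stand for weaker inhibition and lower numbers for stronger inhibition), compound 2 and compound 1 lie within the usual scatter of each other, so these two cannot be ranked. Compound 3 `CCCCCCCCC[C@@H](CCO)n1cnc2c(Cl)ncnc21` has the same atoms and bonds as compound 2 and differs only in configuration as drawn (the two compounds have the same atoms and bonds and differ only in configuration as drawn: 1 of 1 stereo elements differ; a stereocentre at a saturated chain carbon is drawn R in compound 2 and S in compound 3): a stereocentre at a saturated chain carbon is drawn R in compound 2 and S in compound 3. For the measured compounds named here, no measured pair yet shows what such a change does, so no shift beyond the scatter is expected, though a larger one in either direction remains possible. The expected change is a 1.2-fold higher number from compound 2 to compound 3 (0.07 log units; within the scatter) in this assay. The estimate for compound 3 is 1900 nM, with an expected range from 900 nM to 4000 nM.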

Compound 3, half-maximal inhibitory concentration: 3620 nM
For compound 3 the middle estimate is 1.9-fold (0.28 log units) below the measured one, within the range that was stated.
By their numbers in this assay, from the lowest: compounds 2, 1 and 3 (each within the scatter of the next, the first and the last beyond it).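

For the compounds shown here, changing the drawn stereocentre at the saturated chain carbon from R to S gives a 2.2-fold higher number from compound 2 to compound 3 (0.35 log units; beyond the scatter) in this assay and is the first sign that configuration at this carbon can shift the result, if only modestly. The shift can be assigned to that stereocentre alone: the fact that compounds 2 and 3 differ only in the configuration as drawn. By contrast, methyl in place of hydrogen on a saturated chain carbon, nine bonds along the chain from an aromatic nitrogen, gives a 1.6-fold higher number from compound 1 to compound 3 (0.19 log units; within the scatter) and so cannot be called a real change. On these data alone, whether the same gap between R and S appears with a longer chain, or with an amine on the shared core, remains open.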